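Methoxy in Place of Fluoro on Compound 2

The compounds below may be only part of what the source reports. "The series", "measured", "known", "first", "only" and "open" are said of these compounds alone.

Of the compounds shown here, two have so far been tested in a functional assay on the whole organism for inhibition, with Rattus norvegicus as the target, read by paw edema, with stated times of 1 h and 3 h, at a dose of 10 umol/kg by the subcutaneous route; on this read-out lower numbers stand for less inhibition and higher numbers for more inhibition at the one dose given (going by the name of the read-out). Compound 1 `N#Cc1cnn(-c2ccc(S(N)(=O)=O)cc2)c1NC(=O)CCl` gives 40.1%. Compound 2 `N#Cc1cnn(-c2ccc(S(N)(=O)=O)cc2)c1/N=C/c1ccc(F)cc1` gives 36.7% in this assay. Compound 2 thus stands close to compound 1, the gap between the two being within the scatter, so neither compound stands apart from the other on this read-out.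

Compound 3 `COc1ccc(/C=N/c2c(C#N)cnn2-c2ccc(S(N)(=O)=O)cc2)cc1` has not yet been measured in this assay. It differs from compound 2 in one place: methoxy in place of fluoro on an aromatic carbon. The change sits on an aromatic carbon of a six-membered aromatic ring of carbon only.

Among the measured compounds shown here, no step between measured compounds is available to guide an expectation, and the two numbers in hand lie within the scatter of each other. The expectation for compound 3 in this assay is therefore a step of a number 1.3 percentage points higher from compound 2 to compound 3 (within the scatter) of no size beyond the scatter, in no set direction. Compound 3 is estimated at 38% in this assay, with a range from 24% to 52%.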

Compound 3, a percentage reported as inhibition, in the whole organism at one dose (the size of the read-out at that dose, not a potency): 33.6%
Compound 3: the middle estimate sits 4.4 percentage points above what was measured; the range from low to high includes it.
By their numbers in this assay, from the lowest: compounds 3, 2 and 1 (each within the scatter of the next).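

In this assay, among the compounds shown here, the first step between two compounds that differ in one place can now be read: methoxy in place of fluoro, on an aromatic carbon para to a large group, gives a number 3.1 percentage points lower from compound 2 to compound 3 (within the scatter). At this position, the change from 4-fluorophenyl to 4-methoxyphenyl brings in two heavy atoms for one and adds a hydrogen-bond acceptor, yet the read-out at the one dose stays within the scatter, so on this evidence the two groups cannot be told apart. Nothing at hand accounts for this result, and no cause can be assigned to it.

The compounds shown leave open whether a group of another kind at this same place, such as an amine, a carboxylic acid or a longer chain like butoxy, would produce a step beyond the scatter in this assay. They also leave open whether the same exchange of methoxy for fluoro would give a comparable step on an aromatic carbon elsewhere on the ring, where a chloro or a methyl group could equally be set against these two.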